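A few compounds are considered here, and "the series" means these few. Any claim that something is new, unique, unknown or untested is made for them only; others in the source may bear on it.

Measured in a functional assay on QGY7701 cells (Homo sapiens) for cytotoxicity, read by MTT assay, with a stated time of 24 h; a higher number here means a weaker inhibitor, a lower number a stronger inhibitor:
compound 1 `C=CC1=C(C(=O)NC(C)(C)C)C(c2ccc(OC)cc2)OC1`, > 100000 nM
compound 2 `C=CC1=C(C(=O)NCCC)C(c2ccc(OC)c(OC)c2)OC1`, > 100000 nM
compound 3 `C=CC1=C(C(=O)Nc2cccc(C)c2)C(c2ccc(F)cc2)OC1`, 56400 nM.

For compound 1 the value > 100000 nM is a limit of this assay, not a number. For compound 2 the value > 100000 nM is likewise a limit. Among the compounds with values here, compound 3 thus stands alone with the only numerical value in this assay; the other two sit at the limit of > 100000 nM in this assay, at which 2 of the 3 values shown sit.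

Compound 4 `C=CC1=C(C(=O)NC2CCCCC2)C(c2ccc(F)cc2)OC1` differs from compound 3 by cyclohexyl in place of 3-methylphenyl on an amide-type nitrogen. Within the data shown here, no measured pair shares this change, so no measured step guides the size. Among the measured compounds shown here, the expectation for this assay is a step no larger than the scatter, possibly a slight weakening, given that the only number shown sits close to the limit. For compound 4 the estimate is 70000 nM, within 25000 nM to 200000 nM, an expected step of a 1.2-fold higher number from compound 3 to compound 4 (0.09 log units; within the scatter).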

Compound 4, half-maximal inhibitory concentration: 40500 nM
The estimate for compound 4 lay 1.7-fold (0.24 log units) above the measured number; the range from low to high includes it.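

In this assay, cyclohexyl in place of 3-methylphenyl on an amide-type nitrogen gives a 1.4-fold lower number from compound 3 to compound 4 (0.14 log units; within the scatter). Compound 4 therefore has a number rather than a limit, as compound 3 does, so an aromatic ring at this place is not required for a measurable value in this pair. The other compounds cannot be read against this pair, as each differs in more than one place and carries only a limit: the limit of > 100000 nM in this assay, at which 2 of the 4 values shown sit.

From the compounds shown here alone, whether a longer chain, an amine or a carboxylic acid on this nitrogen would give a step beyond the scatter remains open.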